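The source may report more compounds than this note shows. Statements on the series, on what has been measured and on what is new or still open speak of the compounds shown alone.

Measured compounds:
compound 1, `COC[C@H](C(C)C)C(c1ccc(O)c(OC)c1)c1ccc(O)c(OC)c1`, 72000 nM
compound 2, `COc1cc(C(c2ccc(O)c(OC)c2)[C@H](C)[C@@H](C)CF)ccc1O`, 45000 nM
compound 3, `COc1cc(C(c2ccc(O)c(OC)c2)[C@@H](C)[C@H](C)CF)ccc1O`, 32000 nM

All three numbers come from a functional assay on HL-60 cells (Homo sapiens) for cytotoxicity, read by WST assay, with a stated time of 48 h; a higher number here means a weaker inhibitor, a lower number a stronger inhibitor. Compound 3 sits at the low end of the three, though its standing is only partly secure: a 1.4-fold lower number from compound 2 to compound 3 (0.15 log units; within the scatter), and the two compounds differ only in the configuration as drawn (the fact that compounds 2 and 3 differ only in the configuration as drawn). Against compound 1 the gap is clearer: a 2.3-fold lower number from compound 1 to compound 3 (0.35 log units; beyond the scatter), with a 1.6-fold lower number from compound 1 to compound 2 (0.20 log units; within the scatter) pointing the same way.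

Compound 4, `COc1cc(C(c2ccc(O)c(OC)c2)[C@H](C)C(C)C)ccc1O`, is the next step from compound 3: 1,2-dimethylpropyl in place of 2-(fluoromethyl)-1-methylpropyl on a saturated chain carbon bound to two aromatic carbons. The measured steps that bear on it are those from compound 1, in which the same position carried a 1-(methoxymethyl)-2-methylpropyl group and gave the highest number; the present change moves toward a plainer chain without the fluorine. Those steps were small, so in this assay the expected step is a 1.3-fold higher number from compound 3 to compound 4 (0.12 log units; within the scatter), that is, no change beyond the scatter or at most a slight rise. Compound 4 is therefore estimated at 42000 nM, with a range from 20000 nM to 90000 nM.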

Compound 4, half-maximal inhibitory concentration: 17000 nM
Beside the measured number, compound 4's estimate is 2.5-fold (0.39 log units) above it, and the stated range ends above it.
By their numbers in this assay, from the lowest: compounds 4, 3, 2 and 1 (each within the scatter of the next, the first and the last beyond it).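

In this assay the plain 1,2-dimethylpropyl chain loses nothing against the substituted chains, so the level at this position depends on neither the fluoro nor the methoxy group. Hydrogen in place of fluoro gives a step beyond the scatter (a 2.6-fold lower number from compound 2 to compound 4 (0.42 log units; beyond the scatter)), as does hydrogen in place of methoxy (a 4.2-fold lower number from compound 1 to compound 4 (0.63 log units; beyond the scatter)), whereas the fluorine-free chain cannot be separated from its mirror-related fluoromethyl counterpart (a 1.9-fold lower number from compound 3 to compound 4 (0.27 log units; within the scatter)). No fact at hand accounts for these steps.

The compounds shown leave open how a hydroxyl, an amine or a longer chain would read on this saturated chain. They also leave open whether the configuration of the 1,2-dimethylpropyl group matters here, as only one form of it appears.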